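The source may report more compounds than this note shows. Statements on the series, on what has been measured and on what is new or still open speak of the compounds shown alone.

Compound 1 `CCCCNc1nc(NCc2ccccc2)c2ccccc2n1` and compound 2 `c1ccc(CNc2nc(Nc3ccccc3)nc3ccccc23)cc1` share one core, while compound 3 `CCCCNc1nc(NCc2ccccc2)nc2ccccc12` and the still unmeasured compound 4 `c1ccc(CNc2nc(Nc3ccccc3)c3ccccc3n2)cc1` share another; the difference between the two cores is not broken down here. In a physicochemical assay for permeability, using PAMPA, at pH 4 (a higher number here means that the compound crosses the layer faster, a lower number that the compound crosses the layer more slowly), compound 1 gives 161 10^-6 cm/s, compound 2 gives 271 10^-6 cm/s and compound 3 gives 341 10^-6 cm/s. Compound 2 differs from compound 1 by phenyl in place of butyl on a nitrogen on an aromatic ring, and that change made a 1.7-fold higher number from compound 1 to compound 2 (0.23 log units; within the scatter). Compound 4 differs from compound 3 by the same change, (phenyl in place of butyl on a nitrogen on an aromatic ring). For this change a step of similar size is expected in this assay, a 1.3-fold higher number from compound 3 to compound 4 (0.12 log units; within the scatter), because the earlier one made a 1.7-fold higher number from compound 1 to compound 2 (0.23 log units; within the scatter), and that single pair is all the expectation rests on. Compound 4 is therefore estimated at 450 10^-6 cm/s, with a likely range from 250 10^-6 cm/s to 750 10^-6 cm/s.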

Compound 4, apparent permeability: 412 10^-6 cm/s
Compound 4: middle estimate off by 1.1-fold (0.04 log units), on the high side, and the stated range covers the measured number.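

In this assay, phenyl in place of butyl on a nitrogen on an aromatic ring gave a step on the core of compound 3 (a 1.2-fold higher number from compound 3 to compound 4 (0.08 log units; within the scatter)), and the same change gave a step on the core of compound 1 (a 1.7-fold higher number from compound 1 to compound 2 (0.23 log units; within the scatter)). On both cores, then, the change stays within the scatter, so what was seen on one core also held on the other. Two pairs cannot show that the change has a real effect on this read-out or that this would hold on a further core, and nothing measured here speaks to the reason.

The compounds shown leave open whether another group on that nitrogen, such as a longer chain, a cyclohexyl ring or a pyridine ring, would give a step beyond the scatter.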